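A Fluorine for a Chlorine on the Piperazine Phenyl

The source may hold more compounds than are shown below. What is called first, only, known or untested is meant among the compounds shown, and "the series" means these compounds.

Measured compounds:
- Compound 1, `CC1(c2ccccc2)CC(=O)N(CC(=O)N2CCN(c3ccccc3Cl)CC2)C1=O`: "not active" (no number reported)
- Compound 2, `CC1(c2ccccc2)CC(=O)N(CC(=O)N2CCN(c3cccc(C(F)(F)F)c3)CC2)C1=O`: "not active" (no number reported)
- Compound 3, `CC1(c2ccccc2)CC(=O)N(CC(=O)N2CCN(c3ccccc3)CC2)C1=O`: 100 mg/kg

All three share one core and differ only in the group on the phenyl ring attached to the piperazine. In a functional assay on the whole organism (strain CD-1) with Mus musculus as the target, with a stated time of 0.5 h (on this read-out higher numbers stand for an effect only at larger amounts of compound and lower numbers for an effect already at smaller amounts), compound 1 gave "not active" (no number reported), and compound 2 likewise gave "not active" (no number reported); neither came with a number. Only compound 3, which carries an unsubstituted phenyl, gave a number in this assay, namely 100 mg/kg. Compound 1 therefore stands among the two compounds for which no dose could be stated.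

Compound 4, `CC1(c2ccccc2)CC(=O)N(CC(=O)N2CCN(c3ccccc3F)CC2)C1=O`, has not been measured. Its difference from compound 1 is fluoro in place of chloro on an aromatic carbon, on a ring carbon ortho to a large group. Since compound 1 has no number, no size or direction of step from it can be stated; the expectation rests on compound 3 alone. A weak effect, at a dose similar to or larger than that of compound 3, is expected, with a fair chance of no number at all. Compound 4 is expected to give 200 mg/kg in this assay, estimated between 100 mg/kg and 400 mg/kg.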

Compound 4, minimum effective dose: 100 mg/kg
Compound 4: the middle estimate sits 2.0-fold (0.30 log units) above what was measured, within the range that was stated.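

Placing fluoro instead of hydrogen on an aromatic carbon, ortho to a large group, gives no change at the digits printed from compound 3 to compound 4 (within the scatter) in this assay. This place on the ring can therefore hold a small group and still give a dose: compound 4 gives 100 mg/kg, while compound 1, with chloro in the same place, gives "not active" (no number reported). No size can be read for the change from 2-chlorophenyl to 2-fluorophenyl, with a number on one side only, and nothing measured here offers a reason for the contrast.

Open, as far as these compounds go, is how a methyl or a methoxy group would behave on this same ring carbon. Also open, from the compounds shown here alone, is whether a fluoro on another carbon of the phenyl ring would still give a dose like that of compound 4.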